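Working notes: hydroxy to methoxy on compound 2

The source may hold more compounds than are shown below. What is called first, only, known or untested is meant among the compounds shown, and "the series" means these compounds.

Values so far in an ADME assay on Vero cells (Chlorocebus sabaeus) for cytotoxicity, read by MTT assay, with a stated time of 72 h (on this read-out higher numbers stand for lower toxicity in this test and lower numbers for higher toxicity in this test), for three compounds
compound 1 `COc1c(N2CCN(CN3C(=O)C(=O)c4ccccc43)CC2)c(F)cc2c(=O)c(C(=O)O)cn(C3CC3)c12` gives 70800 nM
compound 2 `COc1c(N2CCN(CN3C(=O)/C(=N\O)c4ccccc43)CC2)c(F)cc2c(=O)c(C(=O)O)cn(C3CC3)c12` gives 74400 nM
compound 3 `COc1c(N2CCN(CN3C(=O)/C(=N\O)c4cc(F)ccc43)CC2)c(F)cc2c(=O)c(C(=O)O)cn(C3CC3)c12` gives 73800 nM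

Compound 2 stands level with compound 1 and compound 3, all three values lying within the scatter of one another. The next compound is compound 4 `CO/N=C1\C(=O)N(CN2CCN(c3c(F)cc4c(=O)c(C(=O)O)cn(C5CC5)c4c3OC)CC2)c2ccccc21` in which the change is methyl in place of hydrogen on an oxygen and the group goes from hydroxy to methoxy. For the measured compounds named here, no measured pair shows this change itself. Going by the values given here, two steps bear on it only indirectly: a 1.1-fold higher number from compound 1 to compound 2 (0.02 log units; within the scatter) in the same part of the molecule, and a 1.0-fold lower number from compound 2 to compound 3 (0.00 log units; within the scatter) on an aromatic carbon. Both stay within the scatter, so in this assay no step beyond the scatter is expected and no direction is favoured. The step expected is a 1.0-fold lower number from compound 2 to compound 4 (0.01 log units; within the scatter) with the data offering nothing more specific. For compound 4 the estimated value is 72000 nM with an expected range from 40000 nM to 125000 nM for this estimate.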

Compound 4, half-maximal cytotoxic concentration: 76500 nM
Compound 4: middle estimate off by 1.1-fold (0.03 log units), on the low side; low and high end bracket the measured number.
By their numbers in this assay, from the lowest: compounds 1, 3, 2 and 4 (each within the scatter of the next).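

In this assay the change of hydroxy to methoxy now has a direct reading, which is a 1.0-fold higher number from compound 2 to compound 4 (0.01 log units; within the scatter) for methyl in place of hydrogen on an oxygen whose other neighbour is a double-bonded nitrogen. The earlier steps shown here touched this part of the molecule only indirectly, whereas this pair shows that capping this oxygen with methyl leaves the number within the scatter, so the hydroxy hydrogen is not required to keep the value in this test. Nothing measured alongside this result speaks to why the number holds.

Still open, going by these compounds, is whether a longer chain, a benzyl group or a chain ending in an amine or a carboxylic acid on this oxygen would also stay within the scatter. Also open, on these data alone, is how methoxy on this oxygen reads together with fluoro on the aromatic carbon, as the two changes appear here only apart.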